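A few compounds are considered here, and "the series" means these few. Any claim that something is new, unique, unknown or untested is made for them only; others in the source may bear on it.

Measured compounds so far:

compound 1 `CCC(C(=O)N1CCN(c2cccc(Cl)c2)CC1)N1C(=O)CCC1=O` gives 0%
compound 2 `CCC(C(=O)N1CCN(c2ccccc2F)CC1)N1C(=O)CCC1=O` gives 0%

In a functional assay on the whole organism (strain Swiss) with Mus musculus as the target, in the maximal electroshock model, with a stated time of 2 h, at a dose of 100 mg/kg by the intraperitoneal route (on this read-out higher numbers stand for a stronger effect at the one dose given and lower numbers for a weaker effect), compound 2 stands level with compound 1 at the digits shown. Among the compounds with values here, the only measured step, no change at the digits printed from compound 1 to compound 2 (within the scatter), exchanges 3-chlorophenyl for 2-fluorophenyl on the amine nitrogen in the ring and lies within the scatter; neither compound shows any effect on this read-out at the dose given.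

Compound 3 `CCC(C(=O)N1CCN(c2ccccc2)CC1)N1C(=O)CCC1=O` differs from compound 2 in a single place: hydrogen in place of fluoro on an aromatic carbon. Within the data shown here, the measured step bears on this only loosely, since it swaps one substituted phenyl for another rather than stripping the substituent, and no measured step removes a halogen from this ring. The expectation therefore rests on both measured compounds sitting at the bottom of the scale with no movement between them. A step of no change at the digits printed from compound 2 to compound 3 (within the scatter) is expected, in no direction and none beyond the scatter. Compound 3 is estimated to give 0%, with a range from 0% to 10%.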

Compound 3, a percentage reported as activity, at one dose (the size of the read-out at that dose, not a potency): 0%
The estimate for compound 3 equals the measured number at the digits printed; the range from low to high includes it.
By their numbers in this assay, from the lowest: compounds 1, 2 and 3 (each within the scatter of the next).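

In this assay, hydrogen in place of fluoro on the aromatic carbon gives no change at the digits printed from compound 2 to compound 3 (within the scatter), and hydrogen in place of chloro gives no change at the digits printed from compound 1 to compound 3 (within the scatter). The earlier pair compared only one halogenated phenyl with another, whereas these steps add the plain phenyl and show that, in this set, neither the 2-fluorophenyl nor the 3-chlorophenyl group separates from it on this read-out at the one dose given. No independent measurement on these compounds bears on why the three readings coincide, and all three sit at the bottom of the scale, so the read-out gives no ranking among them.

Still open, on these data alone, is whether a different substituent on this aromatic ring, such as a methoxy group, a trifluoromethyl group or an amine, would give a reading above the bottom of the scale, and whether a change elsewhere in the shared core, such as a longer chain, would do so. With readings from a single dose and a single stated time, these compounds also leave open how the series behaves under other dosing conditions.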